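The source may report more compounds than this note shows. Statements on the series, on what has been measured and on what is new or still open speak of the compounds shown alone.

Notes on the series. In an assay on isolated protein for inhibition of histone deacetylase 8 (Homo sapiens), with a stated time of 1 h (on this read-out higher numbers stand for weaker inhibition and lower numbers for stronger inhibition), compound 1 `COc1cccc(NC(=O)COc2ccc3cc(/C=C4/SC(=O)NC4=O)ccc3c2)c1` gives 7600 nM; compound 3 `O=C(COc1ccc2cc(/C=C3/SC(=O)NC3=O)ccc2c1)Nc1ccccc1` gives 4500 nM, and the two are separated only by a 1.7-fold lower number from compound 1 to compound 3 (0.23 log units; within the scatter), so no order between them is claimed. Compound 2 `O=C(COc1ccc2cc(/C=C3/SC(=O)NC3=O)ccc2c1)Nc1ccccn1` gives > 50000 nM, which is the assay limit of > 50000 nM in this assay, at which 1 of the 3 values shown sits, and not a number. The steps of an at least 6.5-fold higher number from compound 1 to compound 2 (0.81 log units; beyond the scatter) and an at least 11-fold lower number from compound 2 to compound 3 (1.04 log units; beyond the scatter) show that exchanging the aryl group on the amide-type nitrogen can shift this assay well beyond the scatter, whereas removing the methoxy barely moves it. Compound 4 `O=C(COc1ccc2cc(/C=C3/SC(=O)NC3=O)ccc2c1)Nc1ccc(Cl)c(Cl)c1` differs from compound 1 by 3,4-dichlorophenyl in place of 3-methoxyphenyl on an amide-type nitrogen. Going by the values given here, no measured step covers chlorine substituents, so the expected step is a 1.5-fold lower number from compound 1 to compound 4 (0.18 log units; within the scatter), small. Compound 4 is expected near 5000 nM, within 1500 nM to 20000 nM.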

Compound 4, half-maximal inhibitory concentration: > 50000 nM
Compound 4: only a limit was reported (the forecaster's own chance of this, stated with the estimate: 5%); at least 10-fold (1.00 log units) between middle value and limit.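

Compound 4 gives only a limit of the assay in this assay, not a number. Substitution on the phenyl at this amide-type nitrogen can therefore matter well beyond the scatter, even with a ring of carbon only, where the methoxy step alone did not: an at least 6.5-fold higher number from compound 1 to compound 4 (0.81 log units; beyond the scatter), and an at least 11-fold higher number from compound 3 to compound 4 (1.04 log units; beyond the scatter). The step between compound 2 and compound 4 cannot be read, as both sit at the limit: the limit of > 50000 nM in this assay, at which 2 of the 4 values shown sit.

On these data alone, whether one chlorine alone, at either of the two places, already costs this much stays open. So does the effect of an amine or a carboxylic acid on the phenyl.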